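This account rests on a few compounds, and the source may have more. Where it says the series, first, only, none or still open, it means among the compounds named here.

Measured compounds and their results:

Compound 1 `O=C(O)c1cnc2c(F)cccc2c1`: > 25 mg/kg in a functional assay on the whole organism (strain Sprague-Dawley) for inhibition, with Rattus norvegicus as the target (a lower number here means that less compound is needed, a higher number that more compound is needed for the effect), a limit of the assay.
Compound 2 `CCc1ccc2c(=O)c(-c3nn[nH]n3)c[nH]c2c1`: < 5 mg/kg in this assay, also a limit of the assay.
Compound 3 `COc1ccc2ncc(-c3nn[nH]n3)cc2c1`: 10 mg/kg in this assay.

Among the measured compounds shown here, compound 3 stands alone as the only compound of the three with a definite number in this assay. Compound 1 sits at the upper limit of the assay, as recorded in the limit of > 25 mg/kg in this assay, at which 1 of the 3 values shown sits. Compound 2 sits at the lower limit, as recorded in the limit of < 5 mg/kg in this assay, at which 1 of the 3 values shown sits. These two results are limits and not numbers. For the measured compounds named here, no step between measured compounds can be counted, and the position of compound 3 between them is all that the data give.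

The unmeasured compound 4 `CCCCc1ccc2ncc(-c3nn[nH]n3)cc2c1` differs from compound 3 in one place: butyl in place of methoxy on an aromatic carbon. Nothing among the three measured compounds shows how this change acts, since none of them differs from another in this one place.

Compound 4 is therefore expected to lie close to compound 3, with a small step toward a lower minimum effective dose that is expected to be about a 1.7-fold lower number from compound 3 to compound 4 (0.22 log units; within the scatter), at the edge of the usual scatter. Compound 4 is estimated to give 6 mg/kg, with a range from 2 mg/kg to 20 mg/kg.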

Compound 4, minimum effective dose: 5 mg/kg
Compound 4: the middle estimate sits 1.2-fold (0.08 log units) above what was measured; the measured number falls inside the stated range.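

Among the compounds shown here, with butyl in place of methoxy on an aromatic carbon of the shared core, this assay gives the first step that can be read at this position, a 2.0-fold lower number from compound 3 to compound 4 (0.30 log units; within the scatter). The step lies within the scatter, so compound 3 and compound 4 cannot be told apart in this read-out, and the position accepts an open butyl chain made only of carbon in place of a methoxy that holds a hydrogen-bond acceptor, with no difference beyond the scatter. Neither of the two assay limits on record says anything about this exchange, so the data give no measured property that could account for the step.

What the compounds shown leave open is whether any group at this position would move the minimum effective dose beyond the scatter, since only methoxy and butyl can be compared here. An amine, a carboxylic acid or a chain longer than butyl on this same aromatic carbon could answer that, and so could a fluorine, while the present pair says nothing about how any of these would behave.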